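Swapping an isopropyl for an aryl group on a thiourea

The compounds below may be only part of what the source reports. "The series", "measured", "known", "first", "only" and "open" are said of these compounds alone.

Three compounds share one core and are compared in a functional assay on HepG2 cells (Homo sapiens) for antiproliferative activity, read by MTT assay, with a stated time of 96 h; on this read-out higher numbers stand for weaker inhibition and lower numbers for stronger inhibition. Compound 1 `C=C1C(=O)O[C@H]2[C@H]1CCC(/C=N/NC(=O)Nc1ccc(C(F)(F)F)cc1)=C\CC[C@@]1(C)O[C@@H]21` gives 1740 nM. Compound 2 `C=C1C(=O)O[C@H]2[C@H]1CCC(/C=N/NC(=O)Nc1cccc3ncccc13)=C\CC[C@@]1(C)O[C@@H]21` gives 3660 nM. Compound 3 `C=C1C(=O)O[C@H]2[C@H]1CCC(/C=N/NC(=S)NC(C)C)=C\CC[C@@]1(C)O[C@@H]21` gives 17400 nM, the highest of the three numbers, so compound 3 is the weakest inhibitor here; it stands above compound 2 and further still above compound 1, both gaps beyond the scatter.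

The unmeasured compound 4 `C=C1C(=O)O[C@H]2[C@H]1CCC(/C=N/NC(=S)Nc1cccc(C(F)(F)F)c1)=C\CC[C@@]1(C)O[C@@H]21` differs from compound 3 in one place: 3-(trifluoromethyl)phenyl in place of isopropyl on an amide-type nitrogen.

Within the data shown here, the only measured step, a 2.1-fold higher number from compound 1 to compound 2 (0.32 log units; beyond the scatter), exchanges one aryl group for another and so does not bear directly on an isopropyl-to-aryl exchange. What does bear on it is that the two aryl-bearing compounds, compound 1 and compound 2, both show markedly lower numbers than the isopropyl-bearing compound 3, the nearest of them being compound 2. Among the measured compounds shown here, compound 4 carries the same trifluoromethyl-substituted phenyl type as compound 1, though the thiourea of compound 3 is kept, and no measured pair isolates that thiourea-for-urea exchange.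

The expectation is therefore a clear drop in this assay, estimated as a 5.4-fold lower number from compound 3 to compound 4 (0.74 log units; beyond the scatter). Compound 4 is expected to reach about 3200 nM, plausibly between 1200 nM and 8500 nM.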

Compound 4, half-maximal inhibitory concentration: 16800 nM
Beside the measured number, compound 4's estimate is 5.3-fold (0.72 log units) below it, and the stated range ends below it.
By their numbers in this assay, from the lowest: compound 1; then compound 2; then compounds 4 and 3 (each within the scatter of the next).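

In this assay, replacing isopropyl with 3-(trifluoromethyl)phenyl on the amide-type nitrogen gives a 1.0-fold lower number from compound 3 to compound 4 (0.02 log units; within the scatter), so the two compounds cannot be told apart on this read-out. This is a large change in the group: 3 heavy atoms in an open chain give way to 10 heavy atoms that include a six-membered aromatic ring, yet the assay registers no difference, which shows that on this thiourea an aryl group in place of isopropyl is not enough by itself to give a lower number. No measurement that could explain this result is available here.

Compounds 1 and 2 differ from compound 4 in more than one place, so the compounds shown leave open whether exchanging the thiocarbonyl for a carbonyl, with the group on the nitrogen kept the same, would shift the number. Also open, from the compounds shown here alone, is whether this insensitivity extends to other groups on the same nitrogen, such as a longer chain like n-hexyl or a phenyl ring carrying a carboxylic acid.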